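Swapping a Benzyloxy Arm for a Methylcyclohexyl Ring

This account rests on a few compounds, and the source may have more. Where it says the series, first, only, none or still open, it means among the compounds named here.

Two measured compounds share one core and differ at a single spot. Compound 1 `O=C(NCc1ccc(C(F)(F)F)nc1OCC1CCCC1)Nc1cccc2[nH]c(=O)ccc12` and compound 2 `O=C(NCc1ccc(C(F)(F)F)nc1OCc1ccccc1)Nc1cccc2[nH]c(=O)ccc12` were tested in an assay on HEK cells for antagonist activity at transient receptor potential cation channel subfamily V member 1 (Homo sapiens), read by FLIPR; on this read-out lower numbers stand for stronger inhibition and higher numbers for weaker inhibition; compound 1 gives 2.18 nM and compound 2 gives 1.2 nM. That step is a 1.8-fold lower number from compound 1 to compound 2 (0.26 log units; within the scatter), phenyl in place of cyclopentyl on a saturated chain carbon bound to an oxygen on an aromatic ring. Within the data shown here, compound 2 thus holds the lowest of the two numbers, with compound 1 its only neighbour and within the scatter of it.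

Compound 3 `CC1CCC(c2nc(C(F)(F)F)ccc2CNC(=O)Nc2cccc3[nH]c(=O)ccc23)CC1` is not yet measured. Its change from compound 2 is 4-methylcyclohexyl in place of benzyloxy on an aromatic carbon. Among the measured compounds shown here, the one measured step only exchanged the ring at the end of the arm and kept the oxygen; no step tests dropping that oxygen and attaching a saturated ring directly, so it bears on this change only weakly, and the expected result in this assay is a shift no larger than the scatter or a modest rise. Compound 3 is therefore estimated at 3 nM, between 0.8 nM and 12 nM, an expected step of a 2.5-fold higher number from compound 2 to compound 3 (0.40 log units; beyond the scatter).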

Compound 3, half-maximal inhibitory concentration: 1.44 nM
For compound 3 the middle estimate is 2.1-fold (0.32 log units) above the measured one; measured number inside the range.
By their numbers in this assay, from the lowest: compounds 2, 3 and 1 (each within the scatter of the next).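

In this assay, the step of a 1.2-fold higher number from compound 2 to compound 3 (0.08 log units; within the scatter) stays within the scatter, so at this aromatic carbon the benzyloxy arm, with its oxygen and carbon-only aromatic ring, can give way to a directly attached non-aromatic ring with no measurable difference. The step of a 1.5-fold lower number from compound 1 to compound 3 (0.18 log units; within the scatter) is also within the scatter, so 4-methylcyclohexyl matches cyclopentylmethoxy as well, and all three groups, with or without the oxygen, sit at a similar low-nanomolar level. Nothing shown explains this close agreement.

The compounds shown leave open what the oxygen, the ring type and the methyl group each contribute, since the step to compound 3 changes them together. They also leave open whether this tolerance extends to a very different group here, such as an amine or a carboxylic acid.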